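Swapping the Amine Substituents on the Side Chain

This account rests on a few compounds, and the source may have more. Where it says the series, first, only, none or still open, it means among the compounds named here.

Three compounds sharing one core were tested in a functional assay on HepG2 cells (Homo sapiens) for cytotoxicity, read by MTT assay, with a stated time of 72 h; a lower number here means a stronger inhibitor, a higher number a weaker inhibitor. Going by the values given here, compound 1 `COc1c(OCCCCN2CCN(C)CC2)cc(O)c2c(=O)cc(-c3ccc(C(F)(F)F)cc3)oc12` gives 2400 nM there, and compound 2 `COc1ccccc1-c1cc(=O)c2c(O)cc(OCCCCN3CCN(C)CC3)c(OC)c2o1` gives 2330 nM; the single one-point step between them, a 1.0-fold lower number from compound 1 to compound 2 (0.01 log units; within the scatter), changed only the aryl group. Compound 3 `CN(C)CCCOc1c(OCc2ccccc2)cc(O)c2c(=O)cc(-c3ccccc3)oc12` gives 4950 nM in this assay, the highest number of the three, with its gaps to compound 1 and compound 2 both beyond the usual scatter.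

Compound 4 `CCN(CC)CCCOc1c(OCc2ccccc2)cc(O)c2c(=O)cc(-c3ccccc3)oc12` is not yet measured. It differs from compound 3 by diethylamino in place of dimethylamino on a saturated chain carbon, three bonds along the chain from an oxygen on an aromatic ring. Among the compounds with values here, no measured step touches this part of the molecule, and the only step available concerns a different position and stayed within the scatter. With nothing pointing one way or the other, the step from compound 3 to compound 4 is expected to be a 1.0-fold higher number from compound 3 to compound 4 (0.00 log units; within the scatter), that is, no change beyond the scatter. Compound 4 is therefore estimated at 5000 nM in this assay, within a range from 2000 nM to 12500 nM.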

Compound 4, half-maximal inhibitory concentration: 3010 nM
The estimate for compound 4 lay 1.7-fold (0.22 log units) above the measured number; the range from low to high includes it.
By their numbers in this assay, from the lowest: compounds 2, 1, 4 and 3 (each within the scatter of the next, the first and the last beyond it).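

Going by these compounds alone, the step of a 1.6-fold lower number from compound 3 to compound 4 (0.22 log units; within the scatter) in this assay is the first reading of the amine end of this side chain, which the earlier step, confined to the aryl group, did not touch. It shows that replacing dimethylamino with diethylamino, 3 heavy atoms with 5, on a saturated chain carbon, three bonds along the chain from an oxygen on an aromatic ring, does not separate the two compounds beyond the scatter. No supporting measurement is at hand that could explain this result.

On these data alone, whether a primary amine or a dipropylamino group at this place would give a step beyond the scatter remains open. Also open, as far as these compounds go, is whether a chain longer than 3-(diethylamino)propyl would do so, with the benzyloxy-bearing core kept the same.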